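The source may hold more compounds than are shown below. What is called first, only, known or untested is meant among the compounds shown, and "the series" means these compounds.

Measured compounds:
compound 1, `COc1cc(/C=N/Cc2cccnc2)ccc1O`, 30 mg/kg
compound 2, `COc1ccc(/C=N/Cc2cccnc2)cc1O`, 100 mg/kg
compound 3, `O=[N+]([O-])c1ccc(/C=N/Cc2cccnc2)cc1`, 30 mg/kg

In a functional assay on the whole organism (strain Swiss albino) with Mus musculus as the target, with a stated time of 0.5 h (a lower number here means that less compound is needed, a higher number that more compound is needed for the effect), compound 1 gives 30 mg/kg, compound 2 gives 100 mg/kg and compound 3 gives 30 mg/kg. Compound 3 stands level with compound 1 at the digits reported, and together these two carry the lowest numbers of the three. Its nearest neighbour is compound 1, from which it does not differ at the digits reported, a gap that lies within the scatter. Its furthest neighbour is compound 2, whose number is higher by a margin beyond the scatter. Among the compounds with values here, no two of the measured compounds differ in a single place, so no step in this assay has yet been followed directly.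

Compound 4, `C(=N/Cc1cccnc1)\c1ccccc1`, has not yet been measured in this assay. It differs from compound 3 in one place: hydrogen in place of nitro on an aromatic carbon. Within the data shown here, nothing among the measured compounds shows what this change does, so the direction cannot be read from the data. Compound 4 is expected to give 50 mg/kg, within a range from 20 mg/kg to 150 mg/kg. The step that this estimate means, a 1.7-fold higher number from compound 3 to compound 4 (0.22 log units; within the scatter), is expected to be small, not clearly beyond the scatter in either direction.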

Compound 4, minimum effective dose: 100 mg/kg
For compound 4 the middle estimate is 2.0-fold (0.30 log units) below the measured one; the measured number falls inside the stated range.
By their numbers in this assay, from the lowest: compounds 1 and 3 (each within the scatter of the next); then compounds 2 and 4 (each within the scatter of the next).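

In this assay, putting hydrogen in place of nitro on the aromatic carbon para to a group of 9 heavy atoms gives a 3.3-fold higher number from compound 3 to compound 4 (0.52 log units; beyond the scatter), a modest step that nonetheless lies beyond the scatter. Within the data shown here, this is the first change that can be followed at a single place, and it shows that the read-out responds to what sits at this position: of this pair, the nitro compound needs less compound for the effect. What lies behind the step remains unexplained, as no measurement of any property of these compounds bears on it.

A single pair cannot show whether the gain belongs to nitro itself or would also appear with another group at this place, such as an amine, a chlorine atom or a carboxylic acid. Among these compounds, the other compounds offer no further single-place steps, so the effects of their ring substituents cannot be read, and it stays unknown whether this change would give a step of similar size on a differently substituted core.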